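Removing the methyl: compound 3 to compound 4

A few compounds are considered here, and "the series" means these few. Any claim that something is new, unique, unknown or untested is made for them only; others in the source may bear on it.

Compound 3 `Cc1ccc(N2C(=O)COc3ccc(-c4cnc5ccccc5c4)cc32)cc1` is one of three compounds with a reading in a functional assay on MCF7 cells (Homo sapiens) for antiproliferative activity, read by MTT assay, with a stated time of 72 h; on this read-out higher numbers stand for weaker inhibition and lower numbers for stronger inhibition. In this assay compound 3 gives only a limit, > 40000 nM. Compound 1 `COc1ccc(N2C(=O)COc3ccc(-c4cnc5ccccc5c4)cc32)cc1` gives a limit in this assay as well, > 40000 nM. Compound 2 `O=C1COc2ccc(-c3cccc(NS(=O)(=O)c4ccc(F)cc4)c3)cc2N1c1ccccc1` also gives a limit in this assay, > 40000 nM. Thus (the limit of > 40000 nM in this assay, at which 3 of the 3 values shown sit). Among the measured compounds shown here, the single related step, a step that the two limits leave unreadable from compound 1 to compound 3, cannot be read because both ends are limits. Compound 4 `O=C1COc2ccc(-c3cnc4ccccc4c3)cc2N1c1ccccc1` differs from compound 3 by hydrogen in place of methyl on an aromatic carbon. For the measured compounds named here, no measured step on this change is readable, and compound 3 sits at the limit; the step of a number no higher from compound 3 to compound 4 (the limit leaves the size open) is therefore expected to be unreadable rather than a change beyond the scatter. Compound 4 is estimated at 40000 nM, between 15000 nM and 100000 nM, most likely reported again as a limit.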

Compound 4, half-maximal inhibitory concentration: > 40000 nM
Compound 4: only a limit was reported; the forecaster's own chance of this, stated with the estimate: 75%; the middle value lies on the limit itself.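

The steps linking compound 1, compound 3 and compound 4 cannot be read in this assay because both ends of each are limits: the limit of > 40000 nM in this assay, at which 4 of the 4 values shown sit.

The compounds shown leave open whether methoxy, methyl or hydrogen on that aromatic carbon makes any difference to the reading.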